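This account rests on a few compounds, and the source may have more. Where it says the series, first, only, none or still open, it means among the compounds named here.

Compound 1 `CN1Cc2ccc(OCc3ccccc3)cc2[C@@H](O)C1` serves as the reference point for this comparison. In an ADME assay on Vero cells (Chlorocebus sabaeus) for cytotoxicity, read by sulforhodamine B assay, with a stated time of 72 h (a higher number here means a weaker inhibitor, a lower number a stronger inhibitor), compound 1 gives > 100000 nM, and this is a limit of the assay rather than a measured number. Compound 2 `CN1Cc2ccc(OCC3CCNCC3)cc2[C@@H](O)C1` carries a piperidin-4-yl in place of the phenyl of compound 1; in this assay compound 2 gives > 100000 nM, again a limit. The step that the two limits leave unreadable from compound 1 to compound 2 therefore cannot be sized. Compound 3 `CN1Cc2ccc(OCc3ccc(-c4cccc(Cl)c4)cc3)cc2[C@@H](O)C1` adds a 3-chlorophenyl in place of a hydrogen on an aromatic carbon; in this assay compound 3 gives 25500 nM, a real number. Going by the values given here, the step of an at least 3.9-fold lower number from compound 1 to compound 3 (0.59 log units; beyond the scatter) is the only measured step that yields a readable size, and it shows that adding a chlorophenyl ring to the benzyl part of compound 1 moves the value from the limit to a measurable one.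

Compound 4 `CN1Cc2ccc(OCc3cccc(-c4ccc(Cl)cc4)c3)cc2[C@@H](O)C1` has not yet been measured. It differs from compound 1 by 4-chlorophenyl in place of hydrogen on an aromatic carbon. Among the compounds with values here, this change resembles the one from compound 1 to compound 3, so a drop of similar size is expected, though the limit of > 100000 nM in this assay, at which 2 of the 3 values shown sit, leaves the true starting point of compound 1 unknown. Compound 4 is therefore estimated at 30000 nM, with a range from 12000 nM to 100000 nM, which as a step means an expected at least 3.3-fold lower number from compound 1 to compound 4 (0.52 log units; beyond the scatter).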

Compound 4, half-maximal inhibitory concentration: 27300 nM
Compound 4: the middle estimate sits 1.1-fold (0.04 log units) above what was measured, and the stated range covers the measured number.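

Placing a 4-chlorophenyl on an aromatic carbon, meta to a large group, brings in this assay an at least 3.6-fold lower number from compound 1 to compound 4 (0.56 log units; beyond the scatter) and so shows that a readable drop is not confined to the single change seen in compound 3. Among the compounds shown, a chlorophenyl group has now given a real number in two separate structures, compound 3 and compound 4, while compound 1 and compound 2, which do not carry one, both sit at the limit of the assay. As far as these compounds go, the step can only be stated as a minimum, and its true size stays unknown, because the starting value of compound 1 is a limit and not a number: the limit of > 100000 nM in this assay, at which 2 of the 4 values shown sit.

The compounds shown leave open whether the chlorine is needed at all, or whether an unsubstituted phenyl, or a ring carrying a methoxy group, an amine or a carboxylic acid instead, would give a similar result. They also leave open what the 4-chlorophenyl would do at other places on the same ring.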